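A few compounds are considered here, and "the series" means these few. Any claim that something is new, unique, unknown or untested is made for them only; others in the source may bear on it.

Of the compounds shown here, three sharing one core have been measured in an assay on HeLa cells for displacement of a labelled ligand from adenosine receptor A3 (Homo sapiens), read by fluorescence polarization, with a stated time of 30 min; on this read-out higher numbers stand for weaker inhibition and lower numbers for stronger inhibition. Compound 1 `COc1ccc(-c2cc(NC(=O)CCC(=O)NCC(=O)NCc3ccccc3)nc(-c3ccc(OC)cc3)n2)cc1` gives 50800 nM. Compound 2 `COc1ccc(-c2cc(NC(=O)COCC(=O)NCC(=O)NC(C)(C)C)nc(-c3ccc(OC)cc3)n2)cc1` gives 19700 nM, and compound 3 `COc1ccc(-c2cc(NC(=O)COCC(=O)NCC(=O)NC3CCCCC3)nc(-c3ccc(OC)cc3)n2)cc1` gives 21400 nM, the second highest of the three numbers. Within the data shown here, the one single-point step available, a 1.1-fold higher number from compound 2 to compound 3 (0.04 log units; within the scatter), lies within the scatter. Compound 4 `COc1ccc(-c2cc(NC(=O)COCC(=O)NCC(=O)NCc3ccccc3)nc(-c3ccc(OC)cc3)n2)cc1` differs from compound 3 in one place: benzyl in place of cyclohexyl on an amide-type nitrogen. Among the measured compounds shown here, no measured step matches this change exactly; compound 1 also carries a benzyl on that nitrogen, but it differs from compound 4 in its linker as well, so its number can only hint. Because the step of a 1.1-fold higher number from compound 2 to compound 3 (0.04 log units; within the scatter) was small, only a modest shift toward a higher number is expected, a 1.3-fold higher number from compound 3 to compound 4 (0.12 log units; within the scatter). Compound 4 is therefore estimated at 28000 nM, within 12000 nM to 65000 nM.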

Compound 4, inhibition constant: 185000 nM
For compound 4 the middle estimate is 6.6-fold (0.82 log units) below the measured one; measured number outside the range, above it.
By their numbers in this assay, from the lowest: compounds 2 and 3 (each within the scatter of the next); then compound 1; then compound 4.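

Among these compounds, at this amide-type nitrogen the group matters more than the earlier compounds suggested: benzyl in place of cyclohexyl gives an 8.6-fold higher number from compound 3 to compound 4 (0.94 log units; beyond the scatter) and benzyl in place of tert-butyl gives a 9.4-fold higher number from compound 2 to compound 4 (0.97 log units; beyond the scatter) on the inhibition constant, so binding is clearly weaker. Tert-butyl and cyclohexyl could not be told apart, but that equivalence does not extend to benzyl. The available evidence offers no explanation for this shift. The compounds shown leave open whether the aromatic ring or the added carbon accounts for it, which cyclohexylmethyl or phenyl on the same nitrogen could separate.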